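Extending the Dimethylamino Chain from Propyl to Butyl

The compounds below may be only part of what the source reports. "The series", "measured", "known", "first", "only" and "open" are said of these compounds alone.

In a functional assay on A549 cells (Homo sapiens) for antiproliferative activity, read by MTT assay, with a stated time of 48 h (on this read-out lower numbers stand for stronger inhibition and higher numbers for weaker inhibition), compound 3 (`CN(C)CCCn1c(N)c(-c2nc3ccccc3s2)c2nc(C#N)c(C#N)nc21`) gives 8870 nM and compound 1 (`CN(C)CCCCn1c(N)c(-c2nc3ccccc3o2)c2nc(C#N)c(C#N)nc21`) gives 5470 nM; these two values lie within the scatter of each other. Compound 2 (`CN(C)CCn1c(N)c(-c2nc3ccccc3s2)c2nc(C#N)c(C#N)nc21`) reads > 50000 nM, which is a limit of the assay and not a number.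

The next change leads to compound 4 (`CN(C)CCCCn1c(N)c(-c2nc3ccccc3s2)c2nc(C#N)c(C#N)nc21`): (dimethylamino)methyl in place of dimethylamino on a saturated chain carbon, three bonds along the chain from an aromatic nitrogen. Cut one bond further out, this reads 3-(dimethylamino)propyl to 4-(dimethylamino)butyl, on a saturated chain carbon, three bonds along the chain from an aromatic nitrogen.

Among the measured compounds shown here, one measured step bears on it: the same insertion made one bond closer to the aromatic nitrogen gave an at least 5.6-fold lower number from compound 2 to compound 3 (0.75 log units; beyond the scatter). Going by these compounds, that step starts from a limit, so its full size is unknown, and one step sets no trend. Compound 1, which bears the 4-(dimethylamino)butyl chain, gives 5470 nM, so a value of that order looks reachable with this chain. In this assay, a slight move towards a lower number is therefore expected, but none beyond the scatter. The expected change is a 1.6-fold lower number from compound 3 to compound 4 (0.21 log units; within the scatter). Compound 4 is estimated at 5500 nM, with an expected range of 2000 nM to 15000 nM.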

Compound 4, half-maximal inhibitory concentration: 35800 nM
Beside the measured number, compound 4's estimate is 6.5-fold (0.81 log units) below it; the whole stated range lies below it.
By their numbers in this assay, from the lowest: compounds 1 and 3 (each within the scatter of the next); then compound 4. At a limit, above all of these: compound 2.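

In this assay, the insertion on a saturated chain carbon, three bonds along the chain from an aromatic nitrogen, gives a 4.0-fold higher number from compound 3 to compound 4 (0.61 log units; beyond the scatter), which runs against an at least 5.6-fold lower number from compound 2 to compound 3 (0.75 log units; beyond the scatter); among the 1,3-benzothiazol-2-yl compounds, lengthening the chain therefore does not move the number in one direction, and the 3-(dimethylamino)propyl chain of compound 3 has the lowest value. With the 4-(dimethylamino)butyl chain held constant, the exchange on the aromatic carbon gives a 6.5-fold higher number from compound 1 to compound 4 (0.82 log units; beyond the scatter), so the value of compound 1 does not carry over to its 1,3-benzothiazol-2-yl counterpart. The comparison of the two outer chains gives only a floor, an at least 1.3-fold lower number from compound 2 to compound 4 (0.14 log units; that floor lies within the scatter), as it starts from a limit of the assay and not a number: the limit of > 50000 nM in this assay, at which 1 of the 4 values shown sits.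

The compounds shown leave open how the 2-(dimethylamino)ethyl and 3-(dimethylamino)propyl chains behave with the 1,3-benzoxazol-2-yl group, and so whether the same chain dependence holds there. Also open, going by these compounds, is what a longer chain such as 5-(dimethylamino)pentyl, or a pyrrolidine or morpholine in place of the dimethylamino group, would do on the 3-(dimethylamino)propyl framework of compound 3.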